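A Chlorophenyl in Place of Methoxyphenyl on the Shared Core

The compounds below may be only part of what the source reports. "The series", "measured", "known", "first", "only" and "open" are said of these compounds alone.

Measured in an assay on Sf9 cells for inhibition of protein deacetylase HDAC6 (Homo sapiens), read by fluorescence, with a stated time of 40 min; on this read-out lower numbers stand for stronger inhibition and higher numbers for weaker inhibition:
Compound 1 `Cc1ccc(-c2nc(CNc3ccc(C(=O)NO)cc3)n(-c3ccccc3)n2)cc1` gives 224 nM.
Compound 2 `COc1ccc(-n2nc(-c3ccccc3)nc2CNc2ccc(C(=O)NO)cc2)cc1` gives 127 nM.
Compound 3 `COc1ccc(-c2nc(CNc3ccc(C(=O)NO)cc3)n(-c3ccccc3)n2)cc1` gives 163 nM.

Compound 3 stands second highest of the three numbers. Compound 2 lies nearest to it and compound 1 furthest, yet both gaps are within the scatter, so the three compounds cannot be told apart on these numbers. Going by the values given here, the single step between measured compounds, a 1.4-fold lower number from compound 1 to compound 3 (0.14 log units; within the scatter), is also within the scatter.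

Compound 4 `O=C(NO)c1ccc(NCc2nc(-c3cccc(Cl)c3)nn2-c2ccccc2)cc1` differs from compound 3 by 3-chlorophenyl in place of 4-methoxyphenyl on an aromatic carbon. Among the compounds with values here, the only step that bears on this change is the one from compound 1 to compound 3, which alters the group on the same aryl ring and moved the number by little. Within the data shown here, no measured compound carries a chlorine or a 3-substituted phenyl at this place, so the size of the chlorophenyl step is not known from the data. Compound 4 is therefore expected to give a number close to that of compound 3, with the step of a 1.0-fold higher number from compound 3 to compound 4 (0.02 log units; within the scatter) estimated to stay within the scatter. The estimate for compound 4 is 170 nM, in a range from 75 nM to 400 nM.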

Compound 4, half-maximal inhibitory concentration: 115 nM
For compound 4 the middle estimate is 1.5-fold (0.17 log units) above the measured one; the range from low to high includes it.
By their numbers in this assay, from the lowest: compounds 4, 2, 3 and 1 (each within the scatter of the next).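

Up to this point the aromatic carbon of the shared core had carried only 4-methylphenyl and 4-methoxyphenyl, both with the substituent at the same place on the phenyl ring. Compound 4 extends this to a chlorine-bearing 3-substituted phenyl, and in this assay the change gives a 1.4-fold lower number from compound 3 to compound 4 (0.15 log units; within the scatter) and a 1.9-fold lower number from compound 1 to compound 4 (0.29 log units; within the scatter) with neither step leaving the scatter, so this place on the core tolerates all three aryl groups without a measurable change in the number. Nothing available here accounts for the result.

On these data alone, what 4-chlorophenyl or 3-methoxyphenyl would give at this place remains open, which leaves the effect of the chlorine unseparated from that of its place on the ring. Also open, as far as these compounds go, is how an amine or a carboxylic acid on that phenyl ring would read.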